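The compounds below may be only part of what the source reports. "The series", "measured", "known", "first", "only" and "open" are said of these compounds alone.

Measured set in an assay on HEK293 cells for displacement of a labelled ligand from metabotropic glutamate receptor 5 (Rattus norvegicus); a higher number here means a weaker inhibitor, a lower number a stronger inhibitor:
compound 1 `O=C(Nc1cc(-c2ccccc2)nn1-c1ccccc1)c1ccccc1`; compound 1 gives 4180 nM.
compound 2 `O=C(Nc1cc(-c2ccccc2)nn1-c1ccccc1)c1ccc(C(F)(F)F)cc1`; compound 2 gives 990 nM.
compound 3 `O=C(Nc1cc(-c2ccccc2)nn1-c1ccccc1F)c1ccccc1`; compound 3 gives 2700 nM.

Compound 3 stands at the second highest of the three numbers: its gap to compound 1 is within the scatter, while compound 2 lies beyond the scatter below it. Compound 4 `O=C(Nc1cc(-c2ccccc2)nn1-c1ccccc1Cl)c1ccccc1` differs from compound 3 by chloro in place of fluoro on an aromatic carbon. Going by the values given here, no measured step swaps one halogen for another. Among the compounds with values here, the only step on the same ring, a 1.5-fold lower number from compound 1 to compound 3 (0.19 log units; within the scatter), fell within the scatter; the step of a 4.2-fold lower number from compound 1 to compound 2 (0.63 log units; beyond the scatter) sits elsewhere in the molecule and bears only loosely on this change. A step in this assay of about the scatter, in either direction, is therefore expected. For compound 4 the expected value is 2000 nM, range 800 nM to 5000 nM, which amounts to an expected step of a 1.4-fold lower number from compound 3 to compound 4 (0.13 log units; within the scatter).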

Compound 4, inhibition constant: 500 nM
The estimate for compound 4 lay 4.0-fold (0.60 log units) above the measured number, outside the stated range (below it).
By their numbers in this assay, from the lowest: compounds 4 and 2 (each within the scatter of the next); then compounds 3 and 1 (each within the scatter of the next).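

In this assay, this position does not treat the two halogens alike: chloro in place of fluoro gives a 5.4-fold lower number from compound 3 to compound 4 (0.73 log units; beyond the scatter), although fluoro in place of hydrogen stayed within the scatter. Chloro in place of hydrogen on the same aromatic carbon gives an 8.4-fold lower number from compound 1 to compound 4 (0.92 log units; beyond the scatter), so this site, ortho to a large group, can shift the number beyond the scatter. Nothing available explains the difference between chloro and fluoro here.

Going by these compounds, whether bromo, methyl or an amine at this position would behave like chloro remains open. Also open, on these data alone, is whether the chloro of compound 4 and the trifluoromethyl of compound 2 would add up in one molecule.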